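The compounds below may be only part of what the source reports. "The series", "measured", "known", "first", "only" and "open" are said of these compounds alone.

Compound 1 `Cc1cccc(F)c1-c1nc(CN2CCC(C(=O)NCCCN3C[C@H](C)C[C@H](C)C3)CC2)c(C)o1`: > 72 ug/mL; compound 2 `COc1cccc(F)c1-c1nc(CN2CCC(C(=O)NCCCN3C[C@H](C)C[C@H](C)C3)CC2)c(C)o1`: > 74 ug/mL; compound 3 `Cc1cccc(C)c1-c1nc(CN2CCC(C(=O)NCCCN3C[C@H](C)C[C@H](C)C3)CC2)c(C)o1`: 55.9 ug/mL.

In a physicochemical assay for solubility, in phosphate buffer, measured as kinetic solubility, at pH 7.4 (on this read-out lower numbers stand for lower solubility and higher numbers for higher solubility), compound 1 reaches only a limit of the assay, > 72 ug/mL. Compound 2 likewise reaches only a limit, > 74 ug/mL. Compound 3 gives a number, 55.9 ug/mL; the step to it is an at least 1.2-fold lower number from compound 1 to compound 3 (0.10 log units; that floor lies within the scatter) and an at least 1.3-fold lower number from compound 2 to compound 3 (0.12 log units; that floor lies within the scatter).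

The change methoxy in place of methyl on an aromatic carbon gave a step that the two limits leave unreadable from compound 1 to compound 2. The cores of compound 1 and compound 3 differ by methyl in place of fluoro on an aromatic carbon. Compound 4 `COc1cccc(C)c1-c1nc(CN2CCC(C(=O)NCCCN3C[C@H](C)C[C@H](C)C3)CC2)c(C)o1` carries the same kind of change, (methoxy in place of methyl on an aromatic carbon), though here the place is meta to a methyl group rather than meta to a fluoro group.

With the earlier step unreadable, compound 4 is expected to stay near compound 3, whose number is 55.9 ug/mL. The step expected from this is a 1.1-fold higher number from compound 3 to compound 4 (0.03 log units; within the scatter). The estimate for compound 4 is 60 ug/mL, between 30 ug/mL and 110 ug/mL.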

Compound 4, solubility: > 73 ug/mL
Compound 4: no number, only a limit; the forecaster's own chance of this, stated with the estimate: 35%; at least 1.2-fold (0.08 log units) between middle value and limit.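

In this assay, methoxy in place of methyl on an aromatic carbon, carried to the core of compound 3, gives an at least 1.3-fold higher number from compound 3 to compound 4 (0.11 log units; that floor lies within the scatter). The same change on the core of compound 1 leads to compound 2, but that step, like the other steps among compound 1, compound 2 and compound 4, runs between two limits and cannot be read. Within the data shown here, the one readable step is thus a floor on a single core, and it does not show whether the change has the same size on both cores, or any size beyond the scatter.

The compounds shown leave open where compound 1, compound 2 and compound 4 would fall beyond their limits. They also leave open how ethoxy or an amine in place of the methoxy would read in this assay.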